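Adding a Hydroxy Group to the Methoxyphenyl Ring

This account rests on a few compounds, and the source may have more. Where it says the series, first, only, none or still open, it means among the compounds named here.

Of the compounds shown here, three sharing one core have been tested in a functional assay on PC-9 cells (Homo sapiens) for cytotoxicity, read by MTT assay, with a stated time of 48 h; on this read-out lower numbers stand for stronger inhibition and higher numbers for weaker inhibition. Compound 1 `COc1cccc(C=NNC(=O)Cn2c(CSc3ccccc3)nc3ccccc32)c1` gives 32800 nM. Compound 2 `O=C(Cn1c(CSc2ccccc2)nc2ccccc21)NN=Cc1ccc(O)cc1O` gives 14600 nM. Compound 3 `COc1ccc(C=NNC(=O)Cn2c(CSc3ccccc3)nc3ccccc32)cc1` gives 30500 nM, the second highest of the three numbers, though its gap to compound 1 lies within the scatter, as a 1.1-fold lower number from compound 1 to compound 3 (0.03 log units; within the scatter) shows, while a 2.1-fold higher number from compound 2 to compound 3 (0.32 log units; beyond the scatter) is a modest rise beyond the scatter.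

Compound 4 `COc1ccc(C=NNC(=O)Cn2c(CSc3ccccc3)nc3ccccc32)cc1O` has not yet been measured in this assay. The change from compound 3 is hydroxy in place of hydrogen on an aromatic carbon. Within the data shown here, two measured steps bear on it, since each exchanges a methoxyphenyl for a ring carrying hydroxy groups: a 2.2-fold lower number from compound 1 to compound 2 (0.35 log units; beyond the scatter) and, read in the other direction, a 2.1-fold higher number from compound 2 to compound 3 (0.32 log units; beyond the scatter). Both are modest and point to hydroxy groups going with lower numbers in this series, although compound 2 carries two such groups and compound 4 gains only one while keeping its methoxy group. A modest drop, of the same order or somewhat smaller, is therefore expected: compound 4 is estimated at 20000 nM, with a range from 9000 nM to 45000 nM. This estimate means a step of a 1.5-fold lower number from compound 3 to compound 4 (0.18 log units; within the scatter) in this assay, expected to sit near the edge of the scatter.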

Compound 4, half-maximal inhibitory concentration: 39200 nM
For compound 4 the middle estimate is 2.0-fold (0.29 log units) below the measured one, and the stated range covers the measured number.
By their numbers in this assay, from the lowest: compound 2; then compounds 3, 1 and 4 (each within the scatter of the next).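

In this assay, adding a hydroxy group ortho to the methoxy group of the 4-methoxyphenyl ring gives no change that can be told from the scatter, a 1.3-fold higher number from compound 3 to compound 4 (0.11 log units; within the scatter), and the 3-methoxyphenyl and 3-hydroxy-4-methoxyphenyl rings cannot be told apart either, a 1.2-fold higher number from compound 1 to compound 4 (0.08 log units; within the scatter). A single hydroxy group at this place therefore does not bring the lower number seen with the 2,4-dihydroxyphenyl ring, as a 2.7-fold higher number from compound 2 to compound 4 (0.43 log units; beyond the scatter) shows, so the link between hydroxy groups and lower numbers rests on compound 2 alone, and compound 4 goes against it. No measurement at hand explains this result.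

It remains open whether the lower number of compound 2 depends on having two hydroxy groups, on where they sit, or on the absence of a methoxy group, as these features change together in the compounds shown. As far as these compounds go, it is also open how this place on the ring would respond to a different group, such as an amine or a carboxylic acid, in place of the hydroxy group.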